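Removing one methoxy from a benzimidazole-type cytotoxicity probe

The compounds below may be only part of what the source reports. "The series", "measured", "known", "first", "only" and "open" are said of these compounds alone.

Measured compounds:
compound 1, `COc1ccc(-c2nc3cc(C(F)(F)F)ccc3[nH]2)c(OC)c1OC`: 32000 nM
compound 2, `Cn1c(-c2ccc(NC(=O)CN3CCCC3)cc2)nc2cc(C(F)(F)F)ccc21`: 27000 nM

For the measured compounds named here, in an ADME assay on BHK cells (Mesocricetus auratus) for cytotoxicity, read by MTT assay, with a stated time of 96 h (a lower number here means that less compound is tolerated, a higher number that more compound is tolerated), compound 1 gives 32000 nM, the higher of the two numbers so far. Compound 2 gives 27000 nM in this assay, and the gap between the two lies within the scatter, so neither stands apart. Compound 3, `COc1ccc(-c2nc3cc(C(F)(F)F)ccc3[nH]2)c(OC)c1`, has not yet been measured in this assay; it differs from compound 1 by hydrogen in place of methoxy on an aromatic carbon. Going by the values given here, no step between measured compounds shows what such a change does here. The step of a 1.1-fold lower number from compound 1 to compound 3 (0.03 log units; within the scatter) is expected to stay within the scatter, with no clear direction. Compound 3 is therefore estimated at 30000 nM, within 12000 nM to 80000 nM.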

Compound 3, half-maximal cytotoxic concentration: > 100000 nM
Compound 3: no number, only a limit; the forecaster's own chance of this, stated with the estimate: 10%; at least 3.3-fold (0.52 log units) between middle value and limit.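

In this assay, the methoxy ortho to two methoxy groups proves to matter: hydrogen in its place gives an at least 3.1-fold higher number from compound 1 to compound 3 (0.49 log units; beyond the scatter). For compound 3, > 100000 nM is a limit of the assay and not a number. This is the first step at this place, and its full size stays unknown: the limit of > 100000 nM in this assay, at which 1 of the 3 values shown sits.

The compounds shown leave open whether a hydroxy group, an amine or a longer alkoxy chain at this place would read like hydrogen or like methoxy. They also leave open whether removing either remaining methoxy group would give a similar step.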